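This account rests on a few compounds, and the source may have more. Where it says the series, first, only, none or still open, it means among the compounds named here.

In a functional assay on NFS-60 cells (Mus musculus) for inhibition, with a stated time of 72 h (a higher number here means a weaker inhibitor of growth, a lower number a stronger inhibitor of growth), the measured compounds are:
Compound 1 `Nc1ncnc2c(C(=O)Nc3cccc4c3c(Br)nn4Cc3cccnc3)csc12`: 77 nM
Compound 2 `Nc1ncnc2c(C(=O)Nc3cccc4c3c(Br)nn4Cc3cccc(F)n3)csc12`: 233 nM

Compound 2 has the higher number of the two, with a 3.0-fold higher number from compound 1 to compound 2 (0.48 log units; beyond the scatter). Compound 3 `Nc1ncnc2c(C(=O)Nc3cccc4c3c(Br)nn4Cc3cccc(Br)n3)csc12` differs from compound 2 by bromo in place of fluoro on an aromatic carbon. Among the compounds with values here, that single measured step bears on it only loosely, since it exchanges pyridin-3-yl for 6-fluoropyridin-2-yl and no measured step isolates this halogen swap. Going by these compounds, no step beyond the scatter is therefore expected in this assay, and the direction remains open. The estimate means a 1.2-fold lower number from compound 2 to compound 3 (0.07 log units; within the scatter). Compound 3 is expected at 200 nM, with an estimated range of 80 nM to 500 nM.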

Compound 3, concentration for 50% growth inhibition: 243 nM
For compound 3 the middle estimate is 1.2-fold (0.08 log units) below the measured one, and the stated range covers the measured number.
By their numbers in this assay, from the lowest: compound 1; then compounds 2 and 3 (each within the scatter of the next).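

In this assay, 6-bromopyridin-2-yl in place of 6-fluoropyridin-2-yl gives a 1.0-fold higher number from compound 2 to compound 3 (0.02 log units; within the scatter), so the two halogens cannot be told apart at this carbon next to the ring nitrogen. The bromo group also leaves a 3.2-fold higher number from compound 1 to compound 3 (0.50 log units; beyond the scatter), so the separation from the pyridin-3-yl of compound 1 holds with either halogen. No available evidence accounts for this result.

Going by these compounds, whether that separation follows the ring nitrogen's place or the halogen remains open, and a plain pyridin-2-yl would bear on this. Also open, on these data alone, is what a methyl or an amine would give at this carbon.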